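Adding an acetyl group to compound 1

A few compounds are considered here, and "the series" means these few. Any claim that something is new, unique, unknown or untested is made for them only; others in the source may bear on it.

- Compound 1 `COC(=O)/C=C/c1oc(=O)c(COC(C)=O)c(OC)c1CO`: 650 nM
- Compound 2 `COc1c(C)c(/C=C/C(=O)O)oc(=O)c1CO`: > 50000 nM (a limit, not a number)

Among the measured compounds shown here, in a functional assay on HL-60 cells (Homo sapiens) for cytotoxicity (on this read-out lower numbers stand for stronger inhibition and higher numbers for weaker inhibition), compound 1 gives 650 nM, the only exact number so far. The value for compound 2, > 50000 nM, is a limit of the assay. Compound 3 `COC(=O)/C=C/c1oc(=O)c(COC(C)=O)c(OC)c1COC(C)=O` differs from compound 1 by having acetyl in place of hydrogen on an oxygen on a saturated carbon, which changes hydroxymethyl to acetoxymethyl: acetyl in place of hydrogen on an oxygen on a saturated carbon. For the measured compounds named here, no measured step shows the effect of this change. Compound 1, at 650 nM, already carries an acetoxymethyl group, so no step beyond the usual scatter is expected in this assay. The expected result is a 1.3-fold lower number from compound 1 to compound 3 (0.11 log units; within the scatter). For compound 3 the estimated value is 500 nM, with an expected range of 130 nM to 2500 nM.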

Compound 3, half-maximal inhibitory concentration: 520 nM
For compound 3 the middle estimate is 1.0-fold (0.02 log units) below the measured one; the range from low to high includes it.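

In this assay the change of hydroxymethyl to acetoxymethyl gives a 1.3-fold lower number from compound 1 to compound 3 (0.10 log units; within the scatter) and so shows that this oxygen can carry acetyl without a step beyond the usual scatter. The free hydroxy group of compound 1 is therefore not needed to keep this level of activity. Nothing measured here explains why the change has so little effect.

On these data alone, it remains open whether a longer chain on this oxygen, such as butanoyl, would be accepted as well. As far as these compounds go, an amine in place of the hydroxy group is equally open.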